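Aryl urea variation on a shared core

The source may hold more compounds than are shown below. What is called first, only, known or untested is meant among the compounds shown, and "the series" means these compounds.

Compound 1 `Cc1cccc(NC(=O)Nc2nnc(Sc3ncnc4scc(-c5ccncc5)c34)s2)c1`: 20700 nM
Compound 2 `Cc1ccc(NC(=O)Nc2nnc(Sc3ncnc4scc(-c5ccncc5)c34)s2)cc1Cl`: 16000 nM

Both compounds were tested in a functional assay on HepG2 cells (Homo sapiens) for antiproliferative activity, read by MTT assay, with a stated time of 48 h; on this read-out higher numbers stand for weaker inhibition and lower numbers for stronger inhibition. Going by the values given here, compound 2 gives the lower of the two numbers, but the only measured step, a 1.3-fold lower number from compound 1 to compound 2 (0.11 log units; within the scatter), stays within the scatter, so the two compounds cannot be ordered. Compound 3 `O=C(Nc1ccc(Cl)c(C(F)(F)F)c1)Nc1nnc(Sc2ncnc3scc(-c4ccncc4)c23)s1` differs from compound 2 by 4-chloro-3-(trifluoromethyl)phenyl in place of 3-chloro-4-methylphenyl on an amide-type nitrogen. The step from compound 1 to compound 2, which also exchanged one aryl group on the same amide-type nitrogen, is the only one that bears on this change, and it was small. Among the compounds with values here, no measured step replaces a methyl with a trifluoromethyl, so the expectation rests on that single small step. Compound 3 is therefore expected to show only a small step, a 1.3-fold lower number from compound 2 to compound 3 (0.12 log units; within the scatter). For compound 3 the estimate in this assay is 12000 nM, with a range from 4000 nM to 40000 nM.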

Compound 3, half-maximal inhibitory concentration: 45300 nM
Compound 3: the middle estimate sits 3.8-fold (0.58 log units) below what was measured; the measured number lies above the stated range.
By their numbers in this assay, from the lowest: compounds 2 and 1 (each within the scatter of the next); then compound 3.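

In this assay the aryl group on the amide-type nitrogen proves able to move the number beyond the scatter: 4-chloro-3-(trifluoromethyl)phenyl gives a 2.8-fold higher number from compound 2 to compound 3 (0.45 log units; beyond the scatter), in place of 3-chloro-4-methylphenyl. Set against 3-methylphenyl, the same group gives a 2.2-fold higher number from compound 1 to compound 3 (0.34 log units; beyond the scatter), so compound 3 stands apart from both earlier compounds, which themselves cannot be ordered. Nothing available explains why this exchange goes toward weaker inhibition.

The compounds shown leave open whether the higher number follows the trifluoromethyl or the different placing of the chloro, for the exchange alters both at once. Also open, on these data alone, is how an aryl group carrying an amine or a carboxylic acid would read on this nitrogen.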